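This account rests on a few compounds, and the source may have more. Where it says the series, first, only, none or still open, it means among the compounds named here.

Compound 1 `C[C@@H](Nc1c(NCCCCCC(=O)NO)c(=O)c1=O)c1ccccc1` carries a hydroxamic acid chain on one side of its core and a 1-phenylethyl group on the other. In an ADME assay on cells (Hepatocyte, Homo sapiens) for pharmacokinetics, read by LC-MS, with a stated time of 90 min, tested at 1 uM (on this read-out higher numbers stand for fast clearance and lower numbers for slow clearance), compound 1 gives < 5 uL/min, which is a limit of the assay and not a number. Compound 2 `Cc1cccc([C@@H](C)Nc2c(NCCCCCC(=O)NO)c(=O)c2=O)c1` differs from compound 1 by methyl in place of hydrogen on an aromatic carbon, and in this assay compound 2 also gives < 5 uL/min, again a limit of the assay. The step that the two limits leave unreadable from compound 1 to compound 2 therefore cannot be read, since the limit of < 5 uL/min in this assay, at which 2 of the 2 values shown sit, is where both values sit.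

Compound 3 `O=C(CCCCCNc1c(NC2CCCCC2)c(=O)c1=O)NO` changes the other side of the core: cyclohexyl in place of 1-phenylethyl on a nitrogen on an aromatic ring. Going by the values given here, no measured step touches this position, so only the two limits bear on it, and neither shows any movement in this assay. Compound 3 is therefore expected to sit at or close to the same limit, with an estimated value of 4 uL/min, between 1 uL/min and 12 uL/min. The expected step that the limit leaves unreadable from compound 1 to compound 3 is estimated to lie within the scatter of the assay.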

Compound 3, intrinsic clearance in a liver preparation (reported as CLH), per the amount of preparation that the assay uses: < 5 uL/min
Compound 3 ended at the assay's limit (the forecaster's own chance of this, stated with the estimate: 65%); the middle value lies beyond the limit too.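

No step can be read from compound 1 to compound 3 in this assay, since the values of both compounds are limits of the assay and not numbers: the limit of < 5 uL/min in this assay, at which 3 of the 3 values shown sit.

The compounds shown leave open how clearance actually compares among compound 1, compound 2 and compound 3, and which change to the shared core, if any, would give a measurable value in this assay.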